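This account rests on a few compounds, and the source may have more. Where it says the series, first, only, none or still open, it means among the compounds named here.

Measured compounds:
- compound 1, `CCC(C)C(NC(=O)n1nnc2ccccc21)C(=O)NC1CCCCC1`: in a functional assay on SW-620 cells (Homo sapiens) for inhibition (on this read-out lower numbers stand for stronger inhibition and higher numbers for weaker inhibition), compound 1 reaches only the assay limit, > 100000 nM
- compound 2, `CCC(C)C(NC(=O)n1nnc2ccccc21)C(=O)NCc1ccccc1`: compound 2 also stops at the limit, > 100000 nM
- compound 3, `CCC(C)C(NC(=O)n1nnc2ccccc21)C(=O)NC1CCCC1`: compound 3 likewise shows only the limit, > 100000 nM

All three share one core and differ only in the group carried on the amide-type nitrogen. Because every value sits at the limit of > 100000 nM in this assay, at which 3 of the 3 values shown sit, compound 1 has no number of its own, just a limit, and the three measured steps stay unreadable: a step that the two limits leave unreadable from compound 1 to compound 2, a step that the two limits leave unreadable from compound 1 to compound 3 and a step that the two limits leave unreadable from compound 2 to compound 3.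

Compound 4, `CC(C)C(NC(=O)n1nnc2ccccc21)C(=O)NC1CCCCC1`, is the compound to be measured next. It differs from compound 1 by hydrogen in place of methyl on a saturated chain carbon, three bonds along the chain from an amide-type nitrogen and a carbonyl carbon. Within the data shown here, none of the measured steps touches this part of the molecule; they all alter the amide nitrogen instead, so they bear on the new step only by showing that the three known variants give no reading at all. No step beyond the scatter is therefore expected in this assay, in either direction.

Compound 4 is expected to stay near the limit as well, estimated at about 100000 nM, within 30000 nM to 300000 nM. The step this estimate implies, a number no higher from compound 1 to compound 4 (the limit leaves the size open), is expected to be unreadable.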

Compound 4, half-maximal inhibitory concentration: > 100000 nM
Compound 4: no number, only a limit (the forecaster's own chance of this, stated with the estimate: 85%); the middle value sits exactly at the limit.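

In this assay compound 4 gives only a limit, > 100000 nM. Compound 1 has no number of its own either, so no step from it to compound 4 can be read: the limit of > 100000 nM in this assay, at which 4 of the 4 values shown sit.

The compounds shown leave open whether isopropyl in place of sec-butyl changes inhibition at all, and how strongly any of the four inhibits.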